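The source may hold more compounds than are shown below. What is called first, only, known or untested is meant among the compounds shown, and "the series" means these compounds.

Measured in a functional assay on K562 cells (Homo sapiens) for antiproliferative activity, read by MTT assay, with a stated time of 48 h; on this read-out higher numbers stand for weaker inhibition and lower numbers for stronger inhibition:

Compound 1, `CN(C)CCCCn1c(N)c(-c2nc3ccccc3o2)c2nc(C#N)c(C#N)nc21`: 1380 nM
Compound 2, `CCN(CC)CCCCn1c(N)c(-c2nc3ccccc3o2)c2nc(C#N)c(C#N)nc21`: 1980 nM
Compound 3, `CN(C)CCn1c(N)c(-c2nc3ccccc3n2C)c2nc(C#N)c(C#N)nc21`: > 50000 nM, which is a limit of this assay and not a number

Compound 4, `CCN(CC)CCn1c(N)c(-c2nc3ccccc3n2C)c2nc(C#N)c(C#N)nc21`, has not yet been measured in this assay. It differs from compound 3 by a single change: diethylamino in place of dimethylamino on a saturated chain carbon, two bonds along the chain from an aromatic nitrogen. The same kind of change separates the two measured compounds 1 and 2: diethylamino in place of dimethylamino on a saturated chain carbon, four bonds along the chain from an aromatic nitrogen. In that measured pair the step was a 1.4-fold higher number from compound 1 to compound 2 (0.16 log units; within the scatter), so the change made no difference that could be told from repeat measurements. The two places are not identical, though: in compound 1 the amine sits four bonds along the chain from the aromatic nitrogen, in compound 3 only two bonds along it, so the change is the same kind of change rather than the same one.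

Compound 3 and compound 1 also differ in their cores, and that difference is not broken down here. Compound 3 sits at the limit of > 50000 nM in this assay, at which 1 of the 3 values shown sits, so no number is known for it, only that it lies beyond what this assay reports.

For compound 4 the expectation rests on two things: compound 3 gives only a limit, > 50000 nM, and the step of a 1.4-fold higher number from compound 1 to compound 2 (0.16 log units; within the scatter) was within the scatter. The step from compound 3 to compound 4 is therefore expected to be a step that the limit leaves unreadable from compound 3 to compound 4. Compound 4 is estimated at 70000 nM, most likely again reported only as a limit, with a range from 30000 nM to 200000 nM.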

Compound 4, half-maximal inhibitory concentration: > 50000 nM
Compound 4 gave a limit, no number; the forecaster's own chance of this, stated with the estimate: 85%; the middle value does not contradict the limit.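

In this assay compound 4 gives > 50000 nM, which is a limit and not a number. For the compounds shown here, compound 3 stands at a limit as well, so no step between the two compounds can be read: the limit of > 50000 nM in this assay, at which 2 of the 4 values shown sit. The compounds shown leave open how strongly compound 3 and compound 4 actually inhibit, and whether diethylamino in place of dimethylamino makes any difference on their shared core.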